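Swapping the side group on the shared core

The source may report more compounds than this note shows. Statements on the series, on what has been measured and on what is new or still open speak of the compounds shown alone.

Of the compounds shown here, two have been measured in a functional assay on HT-29 cells (Homo sapiens) for antiproliferative activity, with a stated time of 48 h; on this read-out lower numbers stand for stronger inhibition of growth and higher numbers for weaker inhibition of growth. Compound 1 `Cc1cc(O)c(C2=NN(c3ccc(S(N)(=O)=O)cc3)C(c3ccccc3O)C2)cc1Cl` gives 2370 nM. Compound 2 `Cc1cc(O)c(C2=NN(c3ccc(S(N)(=O)=O)cc3)C(/C=C/c3ccccc3)C2)cc1Cl` gives 3730 nM and so has the higher of the two numbers, although the step of a 1.6-fold higher number from compound 1 to compound 2 (0.20 log units; within the scatter) stays within the usual scatter, so the two cannot be told apart on this read-out. Compound 3 `COc1ccc(C2CC(c3cc(Cl)c(C)cc3O)=NN2c2ccc(S(N)(=O)=O)cc2)c(OC)c1OC` has not yet been measured; it differs from compound 2 in one place: 2,3,4-trimethoxyphenyl in place of 2-phenylethenyl on a saturated ring carbon. Among the compounds with values here, the only measured step that bears on this position, from compound 1 to compound 2, exchanged a ring group for a chain group at the same saturated ring carbon and left the number essentially where it was. On that basis compound 3 is expected to show a change of about a 1.2-fold lower number from compound 2 to compound 3 (0.07 log units; within the scatter), which is no shift beyond the scatter. The estimate for compound 3 in this assay is 3200 nM, with a likely range from 1200 nM to 9000 nM.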

Compound 3, concentration for 50% growth inhibition: 1920 nM
Compound 3: the middle estimate sits 1.7-fold (0.22 log units) above what was measured, and the stated range covers the measured number.
By their numbers in this assay, from the lowest: compounds 3, 1 and 2 (each within the scatter of the next).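

At this saturated ring carbon, the change to 2,3,4-trimethoxyphenyl brings a larger group with hydrogen-bond acceptors that 2-phenylethenyl lacks, yet the step stays small in this assay (a 1.9-fold lower number from compound 2 to compound 3 (0.29 log units; within the scatter)). The comparison with the 2-hydroxyphenyl group gives the same picture (a 1.2-fold lower number from compound 1 to compound 3 (0.09 log units; within the scatter)), so three different groups at this position now cannot be told apart on this read-out. Nothing measured here offers an explanation for this.

On these data alone, all three groups carry a six-membered aromatic ring, so it remains open whether an amine, a carboxylic acid or a longer alkyl chain at this carbon would move the number beyond the scatter. As far as these compounds go, the separate contribution of each methoxy group also remains open.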